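Fluoro to Hydroxy: Is the Step Within the Scatter?

The compounds below may be only part of what the source reports. "The series", "measured", "known", "first", "only" and "open" are said of these compounds alone.

Compound 1 `Nc1ncc(Cc2ccccc2I)c(N)n1` gives 8710 nM
Compound 2 `COc1ccccc1Cc1cnc(N)nc1N` gives 28800 nM
Compound 3 `Nc1ncc(Cc2ccccc2F)c(N)n1` gives 43700 nM

In an assay for inhibition of Dihydrofolate reductase (Gallus gallus) (on this read-out lower numbers stand for stronger inhibition and higher numbers for weaker inhibition), compound 3 stands highest of the three numbers; the step of a 1.5-fold higher number from compound 2 to compound 3 (0.18 log units; within the scatter) lies within the scatter, while the step of a 5.0-fold higher number from compound 1 to compound 3 (0.70 log units; beyond the scatter) lies beyond it. Compound 4 `Nc1ncc(Cc2ccccc2O)c(N)n1` differs from compound 3 in one place: hydroxy in place of fluoro on an aromatic carbon. The measured step that bears most on this change is a 1.5-fold higher number from compound 2 to compound 3 (0.18 log units; within the scatter), where an oxygen-bearing substituent gave way to fluoro and the number moved only within the scatter; the steps of a 3.3-fold higher number from compound 1 to compound 2 (0.52 log units; beyond the scatter) and a 5.0-fold higher number from compound 1 to compound 3 (0.70 log units; beyond the scatter) both start from iodo and speak less directly. Since hydroxy, like methoxy, enters through oxygen, no step beyond the scatter is expected. Compound 4 is therefore estimated at 30000 nM, with a range from 12000 nM to 80000 nM. The expected step is a 1.5-fold lower number from compound 3 to compound 4 (0.16 log units; within the scatter).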

Compound 4, inhibition constant: 89100 nM
For compound 4 the middle estimate is 3.0-fold (0.47 log units) below the measured one; the measured number lies above the stated range.
By their numbers in this assay, from the lowest: compound 1; then compounds 2 and 3 (each within the scatter of the next); then compound 4.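

In this assay, this position separates two groups that both enter through oxygen: removing the methyl from the methoxy of compound 2 gave a clear shift (a 3.1-fold higher number from compound 2 to compound 4 (0.49 log units; beyond the scatter)), so hydroxy does not track methoxy here. Hydroxy also parted from fluoro (a 2.0-fold higher number from compound 3 to compound 4 (0.31 log units; beyond the scatter)), although fluoro and methoxy had stayed within the scatter of each other. Against iodo, the change gave the largest step of the set (a 10-fold higher number from compound 1 to compound 4 (1.01 log units; beyond the scatter)). As far as these compounds go, whether an amine or a carboxylic acid here would sit nearer compound 1 or compound 4 stays open. Nothing shown accounts for the high number of compound 4.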